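The source may hold more compounds than are shown below. What is called first, only, known or untested is meant among the compounds shown, and "the series" means these compounds.

Of the compounds shown here, three sharing one core have been measured so far in a physicochemical assay for solubility, using the shake flask method, in phosphate buffer, with a stated time of 24 h, at pH 7.2 (a higher number here means a more soluble compound, a lower number a less soluble compound), for this series. Compound 1 `Cn1c(-c2ccccn2)c(C2CCCCC2)c2ccc(C(=O)NC3(C(=O)Nc4ccc(/C=C/C(=O)O)cc4)CCCCC3)cc21` gives 5 ug/mL as a measured number. Compound 2 `Cn1c(C(N)=O)cc2cc(NC(=O)C(C)(C)NC(=O)c3ccc4c(C5CCCCC5)c(-c5ccccn5)n(C)c4c3)ccc21` gives < 0.1 ug/mL as a limit of the assay and not a number. Compound 3 `Cn1c(-c2ccccn2)c(C2CCCCC2)c2ccc(C(=O)NC(C)(C)C(=O)Nc3ccc(-c4ccc(C(N)=O)o4)cc3)cc21` likewise gives < 0.1 ug/mL as a limit and not a number. Compound 3 thus stands at the limit of < 0.1 ug/mL in this assay, at which 2 of the 3 values shown sit, and no exact figure exists for it.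

Compound 4 `Cn1c(-c2ccccn2)c(C2CCCCC2)c2ccc(C(=O)NC(C)(C)C(=O)Nc3ccc(-c4nc(C(N)=O)cs4)cc3)cc21` differs from compound 3 in one place, with 4-carbamoyl-1,3-thiazol-2-yl in place of 5-carbamoylfuran-2-yl on an aromatic carbon, para to a large group (4-carbamoyl-1,3-thiazol-2-yl in place of 5-carbamoylfuran-2-yl on an aromatic carbon). Within the data shown here, no measured pair shows this swap on its own. The expectation therefore starts from compound 3 at < 0.1 ug/mL as a limit, and no shift beyond the usual scatter is expected. The estimated change is a number no lower from compound 3 to compound 4 (the limit leaves the size open) and stays within that scatter. In this assay compound 4 is estimated at 0.1 ug/mL with a range of 0.03 ug/mL to 0.4 ug/mL expected around it.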

Compound 4, solubility: < 0.1 ug/mL
Compound 4 was reported as a limit; the forecaster's own chance of this, stated with the estimate: 75%; the middle value sits exactly at the limit.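

Compound 3 and compound 4 both give only a limit of the assay and not a number, so no step can be read between them: the limit of < 0.1 ug/mL in this assay, at which 3 of the 4 values shown sit.

In this assay the compounds shown leave open whether 4-carbamoyl-1,3-thiazol-2-yl in place of 5-carbamoylfuran-2-yl makes any difference at all.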